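The source may report more compounds than this note shows. Statements on the series, on what has been measured and on what is new or still open speak of the compounds shown alone.

Three compounds share one core and differ only in the aromatic group attached to it. Compound 1 `Cc1nc(C)n(CC(=O)N2CCN(c3sc(C(F)(F)F)nc3-c3cnc(C(C)(C)C)nc3)C[C@H]2C)n1` gives 1160 nM in an assay on blood for inhibition of C-X-C chemokine receptor type 3 (Homo sapiens), with a stated time of 30 min; a lower number here means a stronger inhibitor, a higher number a weaker inhibitor. Compound 2 `Cc1nc(C)n(CC(=O)N2CCN(c3sc(C(F)(F)F)nc3-c3cnc(N4CCCC4)nc3)C[C@H]2C)n1` gives 352 nM in this assay, and the step of a 3.3-fold lower number from compound 1 to compound 2 (0.52 log units; beyond the scatter) is the only one among the three that is clearly beyond the scatter together with a 4.5-fold higher number from compound 2 to compound 3 (0.65 log units; beyond the scatter). Compound 3 `COc1ccc(-c2nc(C(F)(F)F)sc2N2CCN(C(=O)Cn3nc(C)nc3C)[C@H](C)C2)cn1` gives 1580 nM in this assay, the highest number of the three, though its step of a 1.4-fold higher number from compound 1 to compound 3 (0.13 log units; within the scatter) keeps it within the scatter of compound 1.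

Compound 4 `CCOc1ccc(-c2nc(C(F)(F)F)sc2N2CCN(C(=O)Cn3nc(C)nc3C)[C@H](C)C2)cn1` has not yet been measured in this assay. It differs from compound 3 by methyl in place of hydrogen on a saturated chain carbon bound to an oxygen on an aromatic ring. Within the data shown here, none of the measured steps touches this part of the molecule: each of them exchanges the whole aromatic group rather than the chain on its oxygen. The measured steps thus give no size for this change. Compound 4 is therefore expected to give about 1500 nM in this assay, with a range from 600 nM to 4000 nM. The expected step of a 1.1-fold lower number from compound 3 to compound 4 (0.02 log units; within the scatter) is estimated to lie within the scatter.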

Compound 4, half-maximal inhibitory concentration: 887 nM
For compound 4 the middle estimate is 1.7-fold (0.23 log units) above the measured one; measured number inside the range.
By their numbers in this assay, from the lowest: compound 2; then compounds 4, 1 and 3 (each within the scatter of the next).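

In this assay, among these compounds, methoxy to ethoxy is the first change confined to the chain on the oxygen, and it gives a 1.8-fold lower number from compound 3 to compound 4 (0.25 log units; within the scatter) and so leaves the number within the usual scatter of repeated measurements. With ethoxy in place, the aromatic group exchanges read a 1.3-fold lower number from compound 1 to compound 4 (0.12 log units; within the scatter) and thus stay within the scatter for 2-(tert-butyl)pyrimidin-5-yl, and a 2.5-fold higher number from compound 2 to compound 4 (0.40 log units; beyond the scatter) and thus still favour 2-(pyrrolidin-1-yl)pyrimidin-5-yl over 6-ethoxypyridin-3-yl. No measurement shown here explains these numbers.

On these data alone, whether a longer chain such as propoxy or a branched one such as isopropoxy in place of ethoxy would give a step beyond the scatter remains open. So does whether an amine such as morpholin-4-yl in that place would bring the number close to that of compound 2.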